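The compounds below may be only part of what the source reports. "The series", "measured", "known", "first", "only" and "open" are said of these compounds alone.

Compound 1, `CCc1ccc2nc(C(=O)Nc3c(F)cc(-c4cccc(F)c4)cc3F)c(C)c(O)c2c1`, in a functional assay on Hep 3B2 cells (Homo sapiens) for antiproliferative activity, read by MTT assay, with a stated time of 24 h, tested at 100 ug/mL; a higher number here means a stronger effect of the compound at the concentration tested, a lower number a weaker effect: 63.2%
Compound 2, `Cc1c(C(=O)Nc2ccc(-c3ccccc3)cc2)nc2ccccc2c1O`, in this assay: 84.3%

Going by the values given here, of the two numbers measured so far, compound 2 holds the higher one in this assay; its nearest neighbour is compound 1, whose value lies lower by a gap that is beyond the usual scatter of such measurements.

Compound 3, `Cc1c(C(=O)Nc2ccc(-c3ccccc3)cc2)nc2ccccc2c1C(=O)O`, has not yet been measured in this assay. It differs from compound 2 in a single place: carboxy in place of hydroxy on an aromatic carbon. Both the group that leaves and the group that enters carry one hydrogen-bond donor and one hydrogen-bond acceptor, and the site of the change is on the shared core of compound 2, away from the amide-linked part that compound 1 and compound 2 vary between themselves.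

Among the compounds with values here, no step between measured compounds of this kind exists here, so the direction and size of the change cannot be read from a precedent. The step expected by this account, a number 19.3 percentage points lower from compound 2 to compound 3 (beyond the scatter), is a moderate fall, though one that may not clear the scatter. Compound 3 is accordingly estimated at 65%, with a range from 30% to 90%.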

Compound 3, a percentage reported as inhibition, at one concentration (the size of the read-out at that concentration, not a potency): 44.4%
For compound 3 the middle estimate is 20.6 percentage points above the measured one; the measured number falls inside the stated range.
By their numbers in this assay, from the lowest: compound 3; then compound 1; then compound 2.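

In this assay, going by these compounds alone, the exchange of hydroxy for carboxy on the aromatic carbon opposite the ring nitrogen gives a number 39.9 percentage points lower from compound 2 to compound 3 (beyond the scatter), the first reading of any change at this place on the shared core. The result shows that this position is not indifferent to what it carries: the read-out responds strongly even though the group that leaves and the group that enters have the same hydrogen-bond donor and acceptor counts and neither carries a net charge, so those counts alone do not settle the outcome here. The enters-and-leaves comparison does differ in heavy atoms, with carboxy the larger group, but nothing shown explains why the step takes this direction or size.

With only hydroxy and carboxy shown on this carbon, it remains open whether a methoxy group, an amine or a longer chain would leave the read-out nearer to that of compound 2 or to that of compound 3. Also open, as far as these compounds go, is whether the same exchange would produce a step of similar size on compound 1, which has a different amide-linked part.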